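Cytotoxicity notes on a benzylimidazole anilinobenzoate series

The source may report more compounds than this note shows. Statements on the series, on what has been measured and on what is new or still open speak of the compounds shown alone.

Measured compounds:
compound 1 `COC(=O)c1ccc(NCc2cncn2Cc2ccc(N)cc2)cc1-c1ccccc1`, a toxicity assay on NIH3T3 cells (Mus musculus) for cytotoxicity, read by resazurin assay; a lower number here means that less compound is needed, a higher number that more compound is needed for the effect > 10000 nM
compound 2 `COC(=O)c1ccc(NCc2cncn2Cc2ccc(OC)cc2)cc1-c1ccccc1`, this assay "not determined" (no result reported)
compound 3 `COC(=O)c1ccc(NCc2cncn2Cc2ccc(F)cc2)cc1-c1ccccc1`, this assay "not determined" (no result reported)

Compound 3 has no single number in this assay. Of the other two entries, one is an entry without a number and one is a limit. For compound 1 the reported value is a limit of the assay, not a number: compound 1 gives > 10000 nM. For the measured compounds named here, the only evidence on this assay is therefore (the limit of > 10000 nM in this assay, at which 1 of the 3 values shown sits), and no step between measured compounds can be drawn from it. Compound 2 and compound 3 each stand at "not determined", so nothing about the size or direction of any change can be read from them.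

The next compound, compound 4 `COC(=O)c1ccc(NCc2cncn2Cc2cccc(C(C)(C)C)c2)cc1-c1ccccc1`, differs from compound 3 in one place: 3-(tert-butyl)phenyl in place of 4-fluorophenyl on a saturated chain carbon bound to an aromatic nitrogen. Going by the values given here, with no measured step available, no step size beyond the scatter is expected in either direction; the expectation is that the change leaves the read-out at or near the limit seen for compound 1.

Compound 4 is therefore expected to give about 10000 nM in this assay, with a plausible range from 3000 nM to 30000 nM, and a reported limit rather than a number is considered likely.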

Compound 4, half-maximal effective concentration: > 1000 nM
Compound 4 gave a limit, no number; the forecaster's own chance of this, stated with the estimate: 60%; the middle value does not contradict the limit.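

In this assay compound 4 gives > 1000 nM, a limit and not a number. Compound 1 gives > 10000 nM, also a limit. For the compounds shown here, no step between compound 1 and compound 4 can be read from these two limits. The compounds shown leave open whether 3-(tert-butyl)phenyl in place of 4-aminophenyl changes the read-out at all, and in which direction.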